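Replacing the cyanoguanidine end of compound 1 with a thiourea-type chain

The source may report more compounds than this note shows. Statements on the series, on what has been measured and on what is new or still open speak of the compounds shown alone.

Compound 1 `CC/N=C(/NC#N)NCCCCn1nc(-c2ccccc2)ccc1=O` stands highest of the three numbers in a functional assay on the whole organism with Rattus norvegicus as the target, at a dose of 100 mg/kg (a lower number here means less inhibition, a higher number more inhibition at the dose given (going by the name of the read-out)), where compound 1 gives 58.8%. Compound 2 `CC/N=C(/NC#N)NCCCCn1nc(-c2ccccc2)c(C)cc1=O` gives 38.8% and compound 3 `CC/N=C(/NC#N)NCCCCn1nc(C)ccc1=O` gives 13.5%; both steps from compound 1, a number 20 percentage points lower from compound 1 to compound 2 (beyond the scatter) and a number 45.3 percentage points lower from compound 1 to compound 3 (beyond the scatter), concern the aromatic ring of the shared core. Compound 4 `C/N=C(\S)NCCCCCCn1nc(-c2ccccc2)ccc1=O` differs elsewhere: a group of 7 heavy atoms (4 carbon, 2 nitrogen, 1 sulfur; no ring) in place of a group of 8 heavy atoms (4 carbon, 4 nitrogen; no ring), on a saturated chain carbon, four bonds along the chain from an aromatic nitrogen. Neither measured step touches this part of the molecule, so none bears directly on the change; the account only shows that each measured change on the aromatic ring of the shared core gives a lower number in this assay. With no guide from the data, the estimate for compound 4 is 42% (range 12% to 72%), meaning an expected step of a number 16.8 percentage points lower from compound 1 to compound 4 (beyond the scatter).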

Compound 4, a percentage reported as inhibition, in the whole organism at one dose (the size of the read-out at that dose, not a potency): 22.2%
Compound 4: the middle estimate sits 19.8 percentage points above what was measured; the range from low to high includes it.
By their numbers in this assay, from the lowest: compounds 3 and 4 (each within the scatter of the next); then compound 2; then compound 1.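

In this assay, a change away from the aromatic ring of the shared core also gives a lower number: the group of 7 heavy atoms (4 carbon, 2 nitrogen, 1 sulfur; no ring) in place of the group of 8 heavy atoms (4 carbon, 4 nitrogen; no ring) gives a number 36.6 percentage points lower from compound 1 to compound 4 (beyond the scatter). The read-out is therefore sensitive to what stands at this place on the chain. Nothing available accounts for the step. The compounds shown leave open which part of this change matters. On these data alone, how a urea, an amine or a carboxylic acid would read at this place also remains open.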